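A few compounds are considered here, and "the series" means these few. Any claim that something is new, unique, unknown or untested is made for them only; others in the source may bear on it.

Compound 1 `O=C(Nc1ccc(Cl)cc1)NS(=O)(=O)c1ccc(Cl)s1` sits second of the three numbers in a functional assay on the whole organism (6C3HED cells, Mus musculus) for inhibition, at a dose of 150 mg/kg by the oral route; a higher number here means more inhibition at the dose given (going by the name of the read-out), a lower number less inhibition: compound 1 gives 58%, compound 2 `CCOc1ccc(S(=O)(=O)NC(=O)Nc2ccc(Cl)cc2)s1` gives 69%, and compound 3 `CCCOc1ccc(S(=O)(=O)NC(=O)Nc2ccc(Cl)cc2)s1` gives 44%. The two measured steps out of compound 1, a number 11 percentage points higher from compound 1 to compound 2 (beyond the scatter) and a number 14 percentage points lower from compound 1 to compound 3 (beyond the scatter), run in opposite directions and are both modest; between them, a number 25 percentage points lower from compound 2 to compound 3 (beyond the scatter). Compound 4 `Cc1ccsc1S(=O)(=O)NC(=O)Nc1ccc(Cl)cc1` differs from compound 1 by 3-methylthiophen-2-yl in place of 5-chlorothiophen-2-yl on a sulfonyl sulfur. No measured step touches a methyl on this ring or removes the chlorine without putting an alkoxy in its place, so nothing shown speaks directly to this change; the measured steps only show that changes on this ring move the number modestly higher or modestly lower. The step is therefore expected to be small, a number 8 percentage points lower from compound 1 to compound 4 (within the scatter), with compound 4 estimated at 50%, in the range 25% to 75%.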

Compound 4, a percentage reported as inhibition, in the whole organism at one dose (the size of the read-out at that dose, not a potency): 17%
For compound 4 the middle estimate is 33 percentage points above the measured one, and the stated range ends above it.
By their numbers in this assay, from the lowest: compound 4; then compound 3; then compound 1; then compound 2.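

Placing 3-methylthiophen-2-yl instead of 5-chlorothiophen-2-yl on the sulfonyl sulfur gives a number 41 percentage points lower from compound 1 to compound 4 (beyond the scatter) in this assay, a large step, whereas the ethoxy and propoxy replacements of the chloro moved the number only modestly. A change at this place can therefore remove much of the inhibition at the dose given, even with the heavy-atom count and ring type unchanged. Nothing available accounts for the drop. Going by these compounds, whether the step follows from losing the chloro or from gaining the methyl remains open, and an unsubstituted thiophen-2-yl or a 5-methylthiophen-2-yl group would separate the two.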